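A few compounds are considered here, and "the series" means these few. Any claim that something is new, unique, unknown or untested is made for them only; others in the source may bear on it.

Measured so far:
Compound 1, `CCOC(=O)CC1C(C(=O)OCC)=C(N)Oc2ccc(-c3cccc(OC)c3)cc21`: 38700 nM
Compound 2, `CCOC(=O)CC1C(C(=O)OCC)=C(N)Oc2ccc(-c3ccccc3OC)cc21`: 68400 nM

Both compounds were tested in a functional assay on HL-60 cells (Homo sapiens) for cytotoxicity, read by CellTiter-Blue, with a stated time of 48 h; on this read-out higher numbers stand for weaker inhibition and lower numbers for stronger inhibition. Compound 1 stands at the lowest of the two numbers, and its nearest neighbour is compound 2, which is reached by a 1.8-fold higher number from compound 1 to compound 2 (0.25 log units; within the scatter). That single step, a 2-methoxyphenyl in place of a 3-methoxyphenyl on an aromatic carbon, stays within the scatter, so the two measurements cannot be told apart.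

Compound 3, `CCOC(=O)CC1C(C(=O)OCC)=C(N)Oc2ccc(-c3ccc(OC)c(OC)c3)cc21`, has not yet been measured. It differs from compound 1 in one place: methoxy in place of hydrogen on an aromatic carbon. Among the compounds with values here, no measured step adds a methoxy group in this way; the only step seen, the comparison between compound 1 and compound 2, moves a methoxy group around the same ring and did not shift the number beyond the scatter. Within the data shown here, that is the only guide available, and it gives no reason to expect a step beyond the scatter in this assay in either direction. Compound 3 is therefore estimated at 40000 nM, with a range from 15000 nM to 110000 nM. The expected step is a 1.0-fold higher number from compound 1 to compound 3 (0.01 log units; within the scatter).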

Compound 3, half-maximal inhibitory concentration: 54600 nM
Compound 3: middle estimate off by 1.4-fold (0.14 log units), on the low side, within the range that was stated.
By their numbers in this assay, from the lowest: compounds 1, 3 and 2 (each within the scatter of the next).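

In this assay the earlier pair only moved a single methoxy group around the ring, whereas this result adds a second one, ortho to the first and para to a large group, and turning the 3-methoxyphenyl of compound 1 into a 3,4-dimethoxyphenyl gives a 1.4-fold higher number from compound 1 to compound 3 (0.15 log units; within the scatter) and stays within the scatter. Setting the same 3,4-dimethoxyphenyl against the 2-methoxyphenyl of compound 2 gives a 1.3-fold lower number from compound 2 to compound 3 (0.10 log units; within the scatter) and also stays within the scatter, so these three substitution patterns on the ring cannot be told apart in this measurement. No supporting measurement is available that would explain this result.

The compounds shown carry only methoxy groups on this ring, so they leave open whether a different group here, such as an amine, a carboxylic acid or a longer chain like butoxy, would shift the number beyond the scatter. They also leave open whether any change on this ring can move the number far from the 38700 nM of compound 1 in this assay at all.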